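A Hydroxy-to-Methyl Swap on a Glutamate Receptor Modulator

The source may report more compounds than this note shows. Statements on the series, on what has been measured and on what is new or still open speak of the compounds shown alone.

Measured so far:
Compound 1 `COC(=O)c1ccc(OCCCCOc2ccc(C(=O)CC3CCCC3)c(C)c2C)cc1`: 24.2%
Compound 2 `Cc1c(OCCCCOc2ccc(C(=O)O)c(Cl)c2)ccc(C(=O)CC2CCCC2)c1O`: 40%

Within the data shown here, in an assay on HEK293 cells for positive allosteric modulation of metabotropic glutamate receptor 3 (Rattus norvegicus), read by thallium flux, with a stated time of 2.5 min (on this read-out lower numbers stand for smaller maximal responses and higher numbers for larger maximal responses), compound 2 gives 40%, the higher of the two numbers known. Compound 1 reaches 24.2%, a gap that lies beyond the usual scatter, so compound 2 stands clearly above it.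

Compound 3 `Cc1c(OCCCCOc2ccc(C(=O)O)c(Cl)c2)ccc(C(=O)CC2CCCC2)c1C` has not been measured yet. It differs from compound 2 in one place: methyl in place of hydroxy on an aromatic carbon.

Among the measured compounds shown here, no pair of measured compounds shows this exact change, so there is no measured step to lean on. For the measured compounds named here, with only two numbers in hand, the estimate for compound 3 rests on the values of compound 2 and compound 1 and is necessarily uncertain. The expected step of a number 12 percentage points lower from compound 2 to compound 3 (beyond the scatter) is a moderate fall, near the edge of the scatter. Compound 3 is therefore expected to reach about 28%, within a range from 12% to 48%.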

Compound 3, largest response reached (reported as percent of maximum), in percent of the reference or control that the assay uses: 35.5%
The estimate for compound 3 lay 7.5 percentage points below the measured number, within the range that was stated.
By their numbers in this assay, from the lowest: compound 1; then compounds 3 and 2 (each within the scatter of the next).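

Putting methyl in place of hydroxy on this aromatic carbon comes to a number 4.5 percentage points lower from compound 2 to compound 3 (within the scatter), so in this assay compound 2 and compound 3 cannot be told apart, and a hydroxy here is not required to keep this maximal response. With methyl at this carbon in both compounds, 4-carboxy-3-chlorophenyl in place of 4-(methoxycarbonyl)phenyl on an oxygen on a saturated carbon gives a number 11.3 percentage points higher from compound 1 to compound 3 (beyond the scatter), a modest step that lies beyond the scatter. No measurement shown here explains either step.

Going by these compounds, whether other groups on this aromatic carbon, such as a methoxy or an amine, would fit in the same way remains open. Also open, on these data alone, is how much of the step from the swap at the other end comes from the carboxy group and how much from the chlorine.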